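Swapping the aryl group at the imidazole chain end

This account rests on a few compounds, and the source may have more. Where it says the series, first, only, none or still open, it means among the compounds named here.

Three compounds share a core and differ only in the group on a saturated chain carbon bound to an aromatic carbon. Compound 1 `CCCCc1cnc(CCc2ccc(-c3ccccc3C(=O)O)cc2)[nH]1` gives 93 nM in an in vitro functional assay on cells for agonist activity at Bombesin receptor subtype-3 (Mus musculus), read by luminescence and calcium flux; on this read-out higher numbers stand for an effect only at larger amounts of compound and lower numbers for an effect already at smaller amounts; compound 2 `O=C(O)c1ccccc1-c1ccc(CCc2ncc(CC3CCCCC3)[nH]2)cc1` gives 7.3 nM; compound 3 `N#Cc1ccccc1Cc1cnc(CCc2ccc(-c3ccccc3C(=O)O)cc2)[nH]1` gives 642 nM, the highest number of the three. The steps were a 13-fold lower number from compound 1 to compound 2 (1.11 log units; beyond the scatter), a 6.9-fold higher number from compound 1 to compound 3 (0.84 log units; beyond the scatter) and an 88-fold higher number from compound 2 to compound 3 (1.94 log units; beyond the scatter). Compound 4 `O=C(O)c1ccccc1-c1ccc(CCc2ncc(Cc3cccc(F)c3)[nH]2)cc1` carries 3-fluorophenyl in place of 2-cyanophenyl on a saturated chain carbon bound to an aromatic carbon. For the measured compounds named here, no measured step exchanges one aryl group for another, so the closest guide is compound 3 being the weakest of the set, which suggests the change is expected to lower the number modestly, by a 4.3-fold lower number from compound 3 to compound 4 (0.63 log units; beyond the scatter). Compound 4 is therefore estimated at 150 nM, with a range from 40 nM to 600 nM.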

Compound 4, half-maximal effective concentration: 7.9 nM
Beside the measured number, compound 4's estimate is 19-fold (1.28 log units) above it; the whole stated range lies above it.
By their numbers in this assay, from the lowest: compounds 2 and 4 (each within the scatter of the next); then compound 1; then compound 3.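

An aryl group at this place can give a low number in this assay: moving to 3-fluorophenyl brings an 81-fold lower number from compound 3 to compound 4 (1.91 log units; beyond the scatter) and so the high number of compound 3 does not hold for every aryl group. Replacing cyclohexyl with 3-fluorophenyl gives a 1.1-fold higher number from compound 2 to compound 4 (0.03 log units; within the scatter) and the two groups cannot be told apart here. Replacing propyl with 3-fluorophenyl gives a 12-fold lower number from compound 1 to compound 4 (1.07 log units; beyond the scatter) and the aryl group matches the gain that cyclohexyl brought.

On these data alone, whether the nitrile itself or its place on the ring goes with the high number stays open, as does how an amine or a longer chain would fare here. No measurement shown explains these differences.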